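Fluoro on the Styryl Arm of an Indole Ketone

This account rests on a few compounds, and the source may have more. Where it says the series, first, only, none or still open, it means among the compounds named here.

Measured compounds:
Compound 1, `CC(=O)c1cc(-c2ccc(F)cc2)cc2cc(-c3ccccc3)[nH]c12`, gives 36.4% in a functional assay on MCF7 cells (Homo sapiens) for cytotoxicity, read by MTT assay, with a stated time of 2 days, tested at 100 uM; on this read-out lower numbers stand for a stronger effect and higher numbers for a weaker effect at the one concentration tested.
Compound 2, `CC(=O)c1cc(-c2ccc(F)cc2)cc2cc(-c3ccc(F)cc3)[nH]c12`, gives 20% in this assay.
Compound 3, `CC(=O)c1cc(/C=C/c2ccccc2)cc2cc(-c3ccc(F)cc3)[nH]c12`, gives 50.1% in this assay.

The three compounds share one core and differ at its edges. From compound 1 to compound 2 the change is fluoro in place of hydrogen on an aromatic carbon, and on the cells this shows as a number 16.4 percentage points lower from compound 1 to compound 2 (beyond the scatter). From compound 2 to compound 3 the change is a larger one, and the read-out moves by a number 30.1 percentage points higher from compound 2 to compound 3 (beyond the scatter), leaving compound 3 with the highest number of the three. How the core of compound 3 differs from that of compound 1 is not broken down here.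

Compound 4, `CC(=O)c1cc(/C=C/c2ccc(F)cc2)cc2cc(-c3ccc(F)cc3)[nH]c12`, has not yet been tested. It differs from compound 3 by fluoro in place of hydrogen on an aromatic carbon. Among the compounds with values here, this is the same change as the one from compound 1 to compound 2, at the same kind of place, although cut one bond further out it now reads 2-phenylethenyl to 2-(4-fluorophenyl)ethenyl rather than phenyl to 4-fluorophenyl. Because a number 16.4 percentage points lower from compound 1 to compound 2 (beyond the scatter) was modest, compound 4 is expected to sit somewhat lower than compound 3, with an estimated step of a number 12.1 percentage points lower from compound 3 to compound 4 (beyond the scatter) in this assay. A single earlier instance is a thin basis, so the range is kept wide. Compound 4 is estimated at 38%, between 24% and 54%.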

Compound 4, a percentage reported as activity, at one concentration (the size of the read-out at that concentration, not a potency): 42.2%
The estimate for compound 4 lay 4.2 percentage points below the measured number, and the stated range covers the measured number.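

In this assay, fluoro in place of hydrogen on the 2-phenylethenyl arm gives a number 7.9 percentage points lower from compound 3 to compound 4 (within the scatter), whereas 2-(4-fluorophenyl)ethenyl in place of 4-fluorophenyl gives the clearer step, a number 22.2 percentage points higher from compound 2 to compound 4 (beyond the scatter). Set beside the earlier fluoro step, the new one gives no sign that the change behaves differently on the second core: the same change on two cores in this assay, a number 16.4 percentage points lower (beyond the scatter) from compound 1 to compound 2 and a number 7.9 percentage points lower (within the scatter) from compound 3 to compound 4, 8.5 percentage points apart, within the scatter of two such steps This agreement means only that the two steps cannot be told apart; it does not show that they are equal in size, that fluoro has a real effect on compound 3 when taken alone, or that the change would carry over to any core beyond these two.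

The compounds shown leave open what other groups would do at the same place on the six-membered aromatic ring, such as a chlorine, a methoxy group, an amine or a carboxylic acid, and whether a longer chain could stand in for the 2-phenylethenyl arm. They also leave open how these compounds would compare at any other concentration: each number comes from a single concentration and says only how large the read-out was there, so a stronger or weaker effect can be spoken of only at that concentration.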